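A few compounds are considered here, and "the series" means these few. Any claim that something is new, unique, unknown or untested is made for them only; others in the source may bear on it.

In a physicochemical assay for lipophilicity, at pH 7.4 (a lower number here means a more polar compound, a higher number a more lipophilic compound), compound 1 `COc1cc(-c2nnc3n2CCCC3c2ccc(C(F)(F)F)cc2)ccc1-c1cnc(C)o1` gives 2.9 and compound 2 `COc1cc(-c2nnc3n2CCCC3c2cccc(C(F)(F)F)c2)ccc1-c1cnc(C)o1` gives 2.8 as its value, so compound 2 stands level with compound 1 within the scatter. Still to be measured is compound 3 `COc1cc(-c2nnc3n2CCCC3c2ccccc2C(F)(F)F)ccc1-c1cnc(C)o1` with the difference 2-(trifluoromethyl)phenyl in place of 3-(trifluoromethyl)phenyl on a saturated ring carbon in the form of 2-(trifluoromethyl)phenyl in place of 3-(trifluoromethyl)phenyl on a saturated ring carbon, two ring bonds from the ring nitrogen. Among the measured compounds shown here, the one measured step that bears on this is a number 0.10 log units lower from compound 1 to compound 2 (within the scatter) for the same kind of exchange at the same place. That single step stays within the scatter and does not cover the 2-(trifluoromethyl)phenyl group, so no step beyond the scatter is expected in this assay here, though the margin is kept wide. The estimated step is no change at the digits printed from compound 2 to compound 3 (within the scatter) at this stage. Compound 3 is estimated at 2.8 with an expected range from 2.4 to 3.2 as its upper end.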

Compound 3, distribution coefficient: 3
Beside the measured number, compound 3's estimate is 0.20 log units below it; measured number inside the range.
By their numbers in this assay, from the lowest: compounds 2, 1 and 3 (each within the scatter of the next).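

In this assay, 2-(trifluoromethyl)phenyl on the saturated ring carbon gives a number 0.20 log units higher from compound 2 to compound 3 (within the scatter) and a number 0.10 log units higher from compound 1 to compound 3 (within the scatter). Among the compounds shown here, compound 1, compound 2 and compound 3 therefore all stand level within the scatter, so this position now shows no separation in this assay across all three placements of the trifluoromethyl group, including the one in compound 3 that the earlier pair did not cover. No measured information is available to explain this result.

All three compounds carry the same trifluoromethyl group, so they cannot show whether any change at this carbon can produce a step beyond the scatter. An amine or a carboxylic acid in place of the trifluoromethyl group, or a longer chain at the same carbon, remains an open case for this assay.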